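The compounds below may be only part of what the source reports. "The series", "measured", "known", "first", "only" and "open" are said of these compounds alone.

Compound 1 `O=C(/C=C/c1ccc([N+](=O)[O-])cc1)Nc1cc(Sc2ncn[nH]2)c(O)c2ccccc12`: in a functional assay on HCT-116 cells (Homo sapiens) for antiproliferative activity, read by MTT assay, with a stated time of 48 h (a higher number here means a weaker inhibitor, a lower number a stronger inhibitor), compound 1 gives only the limit > 100000 nM.
Compound 2 `O=C(Nc1cc(Sc2ncn[nH]2)c(O)c2ccccc12)c1cccc(Cl)c1`: in this assay compound 2 gives only the limit > 100000 nM.
Compound 3 `O=C(Nc1cc(Sc2ncn[nH]2)c(O)c2ccccc12)c1ccc([N+](=O)[O-])cc1`: in this assay compound 3 gives only the limit > 100000 nM.

Compound 3 thus stands at the limit, as do both other values shown, and none of them is a number. For the measured compounds named here, the single step between measured compounds, a step that the two limits leave unreadable from compound 2 to compound 3, is not readable; both of its ends are limits. The unmeasured compound 4 `O=C(/C=C/c1ccccc1)Nc1cc(Sc2ncn[nH]2)c(O)c2ccccc12` differs from compound 3 by 2-phenylethenyl in place of 4-nitrophenyl on a carbonyl carbon. Going by the values given here, no measured step bears on this change, and every value shown is the limit of > 100000 nM in this assay, at which 3 of the 3 values shown sit, so neither a direction nor a size can be drawn from them. Compound 4 is therefore expected to stay at the limit as well, its estimated step that the limit leaves unreadable from compound 3 to compound 4 meaning nothing beyond the scatter. The estimate for compound 4 in this assay is 150000 nM, between 50000 nM and 500000 nM.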

Compound 4, half-maximal inhibitory concentration: > 100000 nM
Compound 4: a limit, no number; the forecaster's own chance of this, stated with the estimate: 80%; the middle value is on the limit's open side.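

In this assay compound 4 gives > 100000 nM, which is a limit and not a number. No step from compound 1, compound 2 or compound 3 to compound 4 can be read: the limit of > 100000 nM in this assay, at which 4 of the 4 values shown sit.

The compounds shown leave open which change on the shared core, if any, would give a measurable value.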